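Methoxy for Fluoro on a Second Indole Core

This account rests on a few compounds, and the source may have more. Where it says the series, first, only, none or still open, it means among the compounds named here.

Measured so far:
Compound 1, `CC(=O)c1cc(-c2ccccc2)cc2cc(-c3ccc(F)cc3)[nH]c12`, 85.1%
Compound 2, `COc1ccc(-c2cc3cc(-c4ccccc4)cc(C(C)=O)c3[nH]2)cc1`, 61.5%
Compound 3, `CC(=O)c1cc(/C=C/c2ccc(F)cc2)cc2cc(-c3ccc(F)cc3)[nH]c12`, 53.7%

All three numbers come from a functional assay on HeLa cells (Homo sapiens) for cytotoxicity, read by MTT assay, with a stated time of 2 days, tested at 1 uM; a lower number here means a stronger effect, a higher number a weaker effect of the compound at the concentration tested. Compound 1 and compound 2 differ by methoxy in place of fluoro on an aromatic carbon, and this change gave a number 23.6 percentage points lower from compound 1 to compound 2 (beyond the scatter). Compound 3 carries a different core: compared with compound 1 it shows (2-(4-fluorophenyl)ethenyl in place of phenyl on an aromatic carbon), with a number 31.4 percentage points lower from compound 1 to compound 3 (beyond the scatter). Compound 4, `COc1ccc(-c2cc3cc(/C=C/c4ccc(F)cc4)cc(C(C)=O)c3[nH]2)cc1`, is not yet measured; it differs from compound 3 by methoxy in place of fluoro on an aromatic carbon, the same change already seen between compound 1 and compound 2, at the same place. Because that earlier step was a number 23.6 percentage points lower from compound 1 to compound 2 (beyond the scatter), a step of similar direction is expected here, though the number for compound 3 is already lower, so the expected step is a number 15.7 percentage points lower from compound 3 to compound 4 (beyond the scatter). For compound 4 the estimated value in this assay is 38%, expected between 20% and 58%.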

Compound 4, a percentage reported as activity, at one concentration (the size of the read-out at that concentration, not a potency): 67.1%
Compound 4: the middle estimate sits 29.1 percentage points below what was measured; measured number outside the range, above it.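

In this assay, methoxy in place of fluoro did not carry over from one core to the other, for the new step reads a number 13.4 percentage points higher from compound 3 to compound 4 (beyond the scatter) and the two cores disagree: the same change on two cores in this assay, a number 23.6 percentage points lower (beyond the scatter) from compound 1 to compound 2 and a number 13.4 percentage points higher (beyond the scatter) from compound 3 to compound 4, 37 percentage points apart, beyond the scatter of two such steps. The change of phenyl to 2-(4-fluorophenyl)ethenyl likewise depends on what else the molecule carries, with a number 5.6 percentage points higher from compound 2 to compound 4 (within the scatter) set against the earlier step: the same change on two cores in this assay, a number 31.4 percentage points lower (beyond the scatter) from compound 1 to compound 3 and a number 5.6 percentage points higher (within the scatter) from compound 2 to compound 4, 37 percentage points apart, beyond the scatter of two such steps. So the effects of these two changes do not simply add up across these four compounds, but a single square of compounds cannot show why, nor how either change would behave on any further core.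

Still open, as far as these compounds go, is whether an amine or a carboxylic acid in place of the fluoro would behave like methoxy on either core. A reading at one concentration shows only a stronger or weaker effect at that concentration and leaves open how the four compounds would compare at any other.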